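The compounds below may be only part of what the source reports. "The series", "measured", "known", "first", "only" and "open" are said of these compounds alone.

Measured so far in a functional assay on HeLa cells (Homo sapiens) for antiproliferative activity, read by MTT assay, with a stated time of 48 h; a lower number here means a stronger inhibitor, a higher number a weaker inhibitor:

- Compound 1 `Clc1ccc(-c2nn(-c3ccccc3)cc2-c2nc3ccccc3[nH]2)cc1` gives 1650 nM
- Compound 2 `Clc1ccc(-c2nn(-c3ccccc3)cc2-c2nc3cc(Cl)ccc3[nH]2)cc1` gives 1630 nM
- Compound 3 `FC(F)(F)c1ccc2[nH]c(-c3cn(-c4ccccc4)nc3-c3ccc(Cl)cc3)nc2c1` gives 4420 nM

Compound 3 has the highest number of the three, which makes it the weakest inhibitor in this small set. Compound 4 `COc1ccc(-c2nn(-c3ccccc3)cc2-c2nc3cc(C(F)(F)F)ccc3[nH]2)cc1` differs from it by methoxy in place of chloro on an aromatic carbon. For the measured compounds named here, no measured compound changes this group, so there is no direct guide. The nearest evidence comes from changes elsewhere in the molecule: a 1.0-fold lower number from compound 1 to compound 2 (0.01 log units; within the scatter) and a 2.7-fold higher number from compound 1 to compound 3 (0.43 log units; beyond the scatter) and also a 2.7-fold higher number from compound 2 to compound 3 (0.43 log units; beyond the scatter). These were at most modest, so I expect no large shift and can predict no firm direction. The expected change is a 1.3-fold lower number from compound 3 to compound 4 (0.10 log units; within the scatter) and may well stay within the scatter. For compound 4 the estimated value is 3500 nM with an expected range of 1300 nM to 10000 nM in this assay.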

Compound 4, half-maximal inhibitory concentration: 2760 nM
The estimate for compound 4 lay 1.3-fold (0.10 log units) above the measured number, and the stated range covers the measured number.
By their numbers in this assay, from the lowest: compounds 2, 1, 4 and 3 (each within the scatter of the next, the first and the last beyond it).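

For the compounds shown here, the 4-chlorophenyl group had stayed the same in all the earlier compounds, so this is the first look at that position. Replacing it with 4-methoxyphenyl in this assay gives a 1.6-fold lower number from compound 3 to compound 4 (0.20 log units; within the scatter) and so chloro and methoxy cannot be told apart here, although methoxy carries a hydrogen-bond acceptor and chloro does not. No measurement at hand offers a reason for this result.

As far as these compounds go, whether an amine or a hydroxyl group at this position would give a different number remains open. So does whether methoxy would behave alike in compound 1, which lacks the trifluoromethyl group.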